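Hydroxyl added to the bromophenyl of a semicarbazone

The source may report more compounds than this note shows. Statements on the series, on what has been measured and on what is new or still open speak of the compounds shown alone.

Compound 1 `O=C(N/N=C/c1ccc(Br)cc1)Nc1ccc(Oc2ccnc3[nH]ccc23)c(F)c1` gives 1000 nM in a functional assay on HepG2 cells (Homo sapiens) for antiproliferative activity, read by MTT assay, with a stated time of 72 h (a lower number here means a stronger inhibitor, a higher number a weaker inhibitor), the lowest of the two numbers here. Compound 2 `O=C(N/N=C/c1ccc(Cl)c(Cl)c1)Nc1ccc(Oc2ccnc3[nH]ccc23)c(F)c1` gives 3700 nM in this assay, and the step of a 3.7-fold higher number from compound 1 to compound 2 (0.57 log units; beyond the scatter) is the only measured one. Compound 3 `O=C(N/N=C/c1ccc(O)c(Br)c1)Nc1ccc(Oc2ccnc3[nH]ccc23)c(F)c1` carries a (3-bromo-4-hydroxyphenyl in place of 4-bromophenyl on a carbon with a double bond to nitrogen). Among the measured compounds shown here, no measured step places a hydroxyl on this ring, and the step to compound 2 changes different substituents, so it bears on compound 3 only loosely. Compound 3 is therefore expected near compound 1, at an estimated 1500 nM (range 400 nM to 6000 nM), a step of a 1.5-fold higher number from compound 1 to compound 3 (0.18 log units; within the scatter).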

Compound 3, half-maximal inhibitory concentration: 1360 nM
Estimate against measurement, compound 3: 1.1-fold (0.04 log units) above; the measured number falls inside the stated range.
By their numbers in this assay, from the lowest: compounds 1 and 3 (each within the scatter of the next); then compound 2.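

In this assay the change from 4-bromophenyl to 3-bromo-4-hydroxyphenyl gives a 1.4-fold higher number from compound 1 to compound 3 (0.13 log units; within the scatter) and so leaves the number unmoved at this position, on the carbon with a double bond to nitrogen. The other comparison gives a 2.7-fold lower number from compound 2 to compound 3 (0.43 log units; beyond the scatter) and shows that a second substituent on this ring does not by itself bring the higher number seen with 3,4-dichlorophenyl. No evidence at hand explains either step. The compounds shown leave open what an amine or a methoxy group in place of the hydroxyl would give. They also do not separate the added hydroxyl from the changed place of the bromine.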